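Chain Lengthening on a Quinone Side Chain: Compound 3

The source may report more compounds than this note shows. Statements on the series, on what has been measured and on what is new or still open speak of the compounds shown alone.

The shared core of compound 1 `COc1ccc(OC)c2c1C(=O)C=C(CO)C2=O` carries a hydroxymethyl group on its double-bonded ring carbon. In a functional assay on L1210 cells (Mus musculus) for cytotoxicity (a higher number here means that more compound is needed for the effect, a lower number that less compound is needed), compound 1 gives 0.524 ug/mL. Compound 2 `CCCCC(O)C1=CC(=O)c2c(OC)ccc(OC)c2C1=O` extends that carbon into a butyl-bearing carbinol, and in this assay compound 2 gives 0.412 ug/mL. The step of a 1.3-fold lower number from compound 1 to compound 2 (0.10 log units; within the scatter) shows that this first lengthening barely moved the read-out. Among the two measured numbers, compound 2 holds the lower one, with compound 1 its nearest neighbour and within the scatter of it, so no order between the two can be claimed.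

Compound 3 `CCCCCCCC(O)C1=CC(=O)c2c(OC)ccc(OC)c2C1=O` carries the change (propyl in place of hydrogen on a saturated chain carbon, five bonds along the chain from a double-bonded ring carbon and an oxygen on a saturated carbon).

Within the data shown here, only the step from compound 1 to compound 2 bears on this change, and it lay within the scatter, so a further extension of the same chain by three carbons is expected to give at most a small movement in this assay, with the direction uncertain. Compound 3 is therefore expected at 0.35 ug/mL, within a range from 0.12 ug/mL to 1 ug/mL, meaning an expected step of a 1.2-fold lower number from compound 2 to compound 3 (0.07 log units; within the scatter).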

Compound 3, concentration for half-maximal effect: 1.04 ug/mL
Compound 3: middle estimate off by 3.0-fold (0.47 log units), on the low side, and the stated range ends below it.
By their numbers in this assay, from the lowest: compounds 2, 1 and 3 (each within the scatter of the next, the first and the last beyond it).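

Among these compounds, with the chain on the carbinol carbon extended further, a 2.5-fold higher number from compound 2 to compound 3 (0.40 log units; beyond the scatter) in this assay is the first step at this position to lie beyond the scatter, showing that this position is not indifferent to chain length, as the earlier pair alone might have suggested. Measured against the hydroxymethyl compound, however, the whole change reads a 2.0-fold higher number from compound 1 to compound 3 (0.30 log units; within the scatter) and so sets no order between those two compounds; the separation rests on compound 2 and compound 3 alone, and it is modest in size. Nothing available explains why the added propyl has this effect on the read-out.

Going by these compounds, with so few compounds, it remains open whether the rise in the number continues with a longer chain, such as a decyl group, or whether a hexyl or octyl chain would fit the same trend. Also unresolved is how an amine or a carboxylic acid at the end of the chain would behave, and whether the hydroxyl on the carbinol carbon, kept in both compound 2 and compound 3, has any bearing on this chain-length response.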